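The source may report more compounds than this note shows. Statements on the series, on what has been measured and on what is new or still open speak of the compounds shown alone.

Among the compounds with values here, only two compounds have numbers so far in a functional assay on MDA-MB-231 cells (Homo sapiens) for inhibition; on this read-out higher numbers stand for weaker inhibition and lower numbers for stronger inhibition. Compound 1 (`COC(=O)C(C(=O)OC)C1CC(=O)C=CC12OCC(=O)N2Cc1ccc(Br)cc1`) gives 1230 nM, and compound 2 (`CCSC1CC(=O)CC(SCC)C12OCC(=O)N2Cc1ccc(C)cc1`) gives 1360 nM. These two values lie within the usual scatter of repeated measurements, so compound 2 stands level with compound 1 and neither can be ranked as the better inhibitor.

Compound 3 (`CCSC1CC(=O)CC(SCC)C12OCC(=O)N2Cc1ccc(Cl)cc1`) has not yet been measured. It differs from compound 2 in a single place: chloro in place of methyl on an aromatic carbon. This is chloro in place of methyl on an aromatic carbon, para to a large group, so a 4-methylbenzyl becomes a 4-chlorobenzyl. The rest of the structure stays the same, which makes this a clean comparison.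

Within the data shown here, no two measured compounds differ in only one place, so the data offer no direct guide to the size of such a swap. With nothing pointing either way, no step beyond the scatter is expected in this assay, in either direction. The expected change is a 1.1-fold lower number from compound 2 to compound 3 (0.05 log units; within the scatter). For compound 3 the estimated value is 1200 nM, with an expected range of 550 nM to 2700 nM.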

Compound 3, half-maximal inhibitory concentration: 260 nM
Estimate against measurement, compound 3: 4.6-fold (0.66 log units) above, outside the stated range (below it).
By their numbers in this assay, from the lowest: compound 3; then compounds 1 and 2 (each within the scatter of the next).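

Within the data shown here, this is the first pair in this assay that differs in one place only, and replacing 4-methylbenzyl with 4-chlorobenzyl gives a 5.2-fold lower number from compound 2 to compound 3 (0.72 log units; beyond the scatter) on this read-out. The position is therefore not indifferent to what sits on it: exchanging one heavy atom for one other, with no ring, hydrogen-bond donor, hydrogen-bond acceptor or net charge entering or leaving, moves the number beyond the scatter and makes compound 3 the stronger inhibitor of the pair. Nothing measured here explains why chloro and methyl differ in this way.

As far as these compounds go, a single swap cannot show whether this result is particular to chloro, so it remains open how fluoro, trifluoromethyl or methoxy would fare in the same place on the core of compound 3. From the compounds shown here alone, it is also open whether the same change would give a step of similar size on a different core, such as that of compound 1.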